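Working notes on the step from compound 2 to compound 3

The compounds below may be only part of what the source reports. "The series", "measured", "known", "first", "only" and "open" are said of these compounds alone.

The series is followed in a functional assay on the whole organism (strain Wistar albino) for inhibition, with Rattus norvegicus as the target, read by paw edema, with stated times of 30 min and 3 h, at a dose of 0.05 mmol/kg; a lower number here means less inhibition, a higher number more inhibition at the dose given (going by the name of the read-out). Compound 1 `NS(=O)(=O)c1ccc(N2N=C(c3cccc(O)c3)C[C@H]2c2ccccc2)cc1` gives 35.8%. For the measured compounds named here, compound 2 `NS(=O)(=O)c1ccc(N2N=C(c3cccc(O)c3)C[C@H]2c2ccc(O)cc2)cc1` gives 64.7%, the higher of the two numbers measured so far; its only neighbour is compound 1, and the step of a number 28.9 percentage points higher from compound 1 to compound 2 (beyond the scatter), hydroxy in place of hydrogen on an aromatic carbon, is the single measured step that bears on what follows. Compound 3 `NS(=O)(=O)c1ccc(N2N=C(c3cccc(O)c3)C[C@H]2c2ccccc2Cl)cc1` is unmeasured. Its change from compound 2 is 2-chlorophenyl in place of 4-hydroxyphenyl on a saturated ring carbon. Going by the values given here, the 4-hydroxyphenyl group that leaves is the same group whose arrival gave the step from compound 1 to compound 2; the 2-chlorophenyl group that enters has no measured counterpart here. The expectation is therefore a drop in this assay of about the size of that step, with added uncertainty for the chlorine, so compound 3 is expected at 40%, between 25% and 58%, which means a step of a number 24.7 percentage points lower from compound 2 to compound 3 (beyond the scatter).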

Compound 3, a percentage reported as inhibition, in the whole organism at one dose (the size of the read-out at that dose, not a potency): 32.6%
Estimate against measurement, compound 3: 7.4 percentage points above; measured number inside the range.
By their numbers in this assay, from the lowest: compounds 3 and 1 (each within the scatter of the next); then compound 2.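

In this assay, the 2-chlorophenyl group on the saturated ring carbon gives a number 32.1 percentage points lower from compound 2 to compound 3 (beyond the scatter), so the higher number of compound 2 does not carry over to this replacement of the 4-hydroxyphenyl group. Chloro in place of hydrogen on the aromatic carbon gives a number 3.2 percentage points lower from compound 1 to compound 3 (within the scatter), which leaves compound 3 and compound 1 indistinguishable, and of the three groups at this position only the 4-hydroxyphenyl group stands apart. Nothing available explains this difference between the groups.

These compounds leave open whether the higher number depends on the hydroxy group itself or would also appear with another group in its place, such as a methoxy group or an amine on the same phenyl ring. They also leave open whether chloro would behave the same way elsewhere on that ring.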